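Hydroxy removal on the compound 1 core

The source may report more compounds than this note shows. Statements on the series, on what has been measured and on what is new or still open speak of the compounds shown alone.

Measured so far in a functional assay on the whole organism (stomach) for inhibition, with Rattus norvegicus as the target; on this read-out lower numbers stand for an effect already at smaller amounts and higher numbers for an effect only at larger amounts of compound:
- compound 1, `Cc1cc(F)ccc1Nc1nc(N(C)c2ccccc2)c2cc(O)ccc2n1`, gives 1.5 umol/kg
- compound 2, `Cc1ccccc1Nc1nc(N)nc2ccccc12`, gives 48 umol/kg

Compound 1 stands at the lowest number of the two measured; compound 2 sits beyond the scatter at a markedly higher number. Going by the values given here, no pair of measured compounds differs in a single place, so no step has been worked out; compound 1 and compound 2 differ in several places at once, and their two values show only that the compound 1 pattern sits at the smaller dose.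

Compound 3, `Cc1cc(F)ccc1Nc1nc(N(C)c2ccccc2)c2ccccc2n1`, has not been measured. It differs from compound 1 by hydrogen in place of hydroxy on an aromatic carbon of the shared core. Among the compounds with values here, with no measured step of this kind available, the size of the change is uncertain; a modest move toward a higher number, near the edge of the scatter, is expected rather than a large one. The step of a 2.0-fold higher number from compound 1 to compound 3 (0.30 log units; within the scatter) is the estimated outcome. Compound 3 is thus expected to give about 3 umol/kg, within a range from 0.8 umol/kg to 12 umol/kg.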

Compound 3, dose for half-maximal effect: 1.94 umol/kg
Estimate against measurement, compound 3: 1.5-fold (0.19 log units) above, and the stated range covers the measured number.
By their numbers in this assay, from the lowest: compounds 1 and 3 (each within the scatter of the next); then compound 2.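

Going by these compounds alone, replacing hydroxy with hydrogen on this aromatic carbon of the shared core gives the first step that can be read: in this assay, a 1.3-fold higher number from compound 1 to compound 3 (0.11 log units; within the scatter). The opening values could not separate this position from the other differences between the compounds, but this step isolates it and shows that, on the core of compound 1, the hydroxy is not required for a value at this level, since the two numbers cannot be told apart on this read-out. No measurement available here explains why this exchange leaves the two numbers within the scatter of each other.

On these data alone, this single step covers only hydroxy and hydrogen at one place on one core, so it remains open whether a methoxy, an amine or a carboxylic acid on the same aromatic carbon would also stay within the scatter of compound 1. As far as these compounds go, it is equally open whether the same exchange would give a step of similar size on a core carrying other groups elsewhere.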